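The source may report more compounds than this note shows. Statements on the series, on what has been measured and on what is new or still open speak of the compounds shown alone.

Compound 1 `COc1ccc(-c2nc(-c3ccccc3)c(-c3ccc4c(c3)NC(=O)CO4)[nH]2)cc1`: 96%
Compound 2 `COc1ccc(-n2cc(-c3ccccc3)c(-c3ccc4c(c3)NC(=O)CO4)n2)cc1`: 92.2%

In a functional assay on DLD-1 cells (Homo sapiens) for cytotoxicity, read by colorimetric assay and MTT assay, with a stated time of 3 days, tested at 1 uM (on this read-out lower numbers stand for a stronger effect and higher numbers for a weaker effect at the one concentration tested), compound 2 gives 92.2%, and compound 1 gives 96%, so the two numbers sit within the scatter of each other, both near the weak end of the read-out. Compound 3 `Cc1ccccc1-n1cc(-c2ccccc2)c(-c2ccc3c(c2)NC(=O)CO3)n1` differs from compound 2 by 2-methylphenyl in place of 4-methoxyphenyl on an aromatic nitrogen. For the measured compounds named here, no step between measured compounds is available to guide the size of this change. The account therefore expects no step beyond the scatter, a number 0.8 percentage points higher from compound 2 to compound 3 (within the scatter). Compound 3 is estimated at 93%, within a range from 80% to 102%.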

Compound 3, a percentage reported as activity, at one concentration (the size of the read-out at that concentration, not a potency): 92.2%
Compound 3: middle estimate off by 0.8 percentage points, on the high side; low and high end bracket the measured number.
By their numbers in this assay, from the lowest: compounds 2, 3 and 1 (each within the scatter of the next).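

In this assay, for the compounds shown here, 2-methylphenyl in place of 4-methoxyphenyl on an aromatic nitrogen gives no change at the digits printed from compound 2 to compound 3 (within the scatter) and is the first step that can be read at this position. The exchange removes the hydrogen-bond acceptor of the 4-methoxyphenyl group, yet the read-out stays near the weak end. Nothing measured here offers an explanation for this result. The compounds shown leave open whether a group other than a substituted phenyl on this nitrogen, such as a simple methyl or a chain carrying an amine, would move the read-out. Also open, going by these compounds, is whether a carboxylic acid on the phenyl ring at this position would do so.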